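A hydroxy group added to compound 2

The source may report more compounds than this note shows. Statements on the series, on what has been measured and on what is new or still open speak of the compounds shown alone.

Measured so far in a functional assay on HepG2 cells (Homo sapiens) for inhibition, read by MTT assay, with a stated time of 48 h; on this read-out higher numbers stand for weaker inhibition and lower numbers for stronger inhibition:
- compound 1 `COc1ccc(-n2c(SCc3ccc(C)cc3)nnc2-c2cc(OC)c(OC)c(OC)c2)cc1` gives 31600 nM
- compound 2 `COc1ccc(C(=O)CSc2nnc(-c3cc(OC)c(OC)c(OC)c3)n2-c2ccc(OC)cc2)cc1` gives 18100 nM

Among the measured compounds shown here, only one measured step exists (a 1.7-fold lower number from compound 1 to compound 2 (0.24 log units; within the scatter)) and it stays within the scatter, so compound 2 stands level with the one other measured compound. Compound 3 `COc1ccc(-n2c(SCC(=O)c3ccc(OC)c(O)c3)nnc2-c2cc(OC)c(OC)c(OC)c2)cc1` differs from compound 2 by hydroxy in place of hydrogen on an aromatic carbon and is not yet measured. For the measured compounds named here, that single step changed the same side chain, yet no measured step tests a hydroxy group on an aromatic carbon. The expected outcome is therefore no shift beyond the scatter (a 1.3-fold lower number from compound 2 to compound 3 (0.11 log units; within the scatter)) in this assay and the uncertainty is wide. Compound 3 is estimated near 14000 nM (expected range 3500 nM to 40000 nM).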

Compound 3, half-maximal inhibitory concentration: > 60000 nM
Compound 3: a limit, no number (the forecaster's own chance of this, stated with the estimate: 10%); middle value at least 4.2-fold (0.63 log units) away from the limit.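

In this assay compound 3 gives > 60000 nM, which is a limit of the assay and not a number. Hydroxy on the aromatic carbon ortho to a methoxy group is the first change shown to go beyond the scatter, with an at least 3.3-fold higher number from compound 2 to compound 3 (0.52 log units; beyond the scatter), so this position does not tolerate the change in this assay. Against the 4-methylphenyl side chain, the result is an at least 1.8-fold higher number from compound 1 to compound 3 (0.27 log units; that floor lies within the scatter), which separates neither side chain from the other. Open, going by these compounds, is whether an amine or a fluorine atom on the same aromatic carbon would weaken inhibition likewise, and how far the true value of compound 3 lies past its limit.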